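The source may report more compounds than this note shows. Statements on the series, on what has been measured and on what is new or still open speak of the compounds shown alone.

Compound 1 `CCc1ccc(-n2nc(-c3ccc(C(F)(F)F)cc3O)nc2-c2ccccc2O)cc1` — 107%
Compound 2 `Oc1cc(C(F)(F)F)ccc1-c1nc(-c2ccccc2O)n(-c2ccc(F)cc2)n1` — 99.8%
Compound 3 `Oc1cc(C(F)(F)F)ccc1-c1nc(-c2ccccc2O)n(-c2ccc(C(F)(F)F)cc2)n1` — 102%

In a functional assay on PC-12 cells (Rattus norvegicus) for cytotoxicity, read by MTT assay, with stated times of 2 h and 24 h, tested at 10 uM (on this read-out lower numbers stand for a weaker effect and higher numbers for a stronger effect at the one concentration tested), compound 2 gives the lowest of the three numbers, yet its steps to the others, a number 7.2 percentage points lower from compound 1 to compound 2 (within the scatter) and a number 2.2 percentage points higher from compound 2 to compound 3 (within the scatter), both lie within the scatter, so the three compounds cannot be told apart. Compound 4 `COc1ccc(-n2nc(-c3ccc(C(F)(F)F)cc3O)nc2-c2ccccc2O)cc1` differs from compound 2 by methoxy in place of fluoro on an aromatic carbon. The measured steps that bear on this change are the exchanges at the same aromatic carbon: a number 7.2 percentage points lower from compound 1 to compound 2 (within the scatter), a number 5 percentage points lower from compound 1 to compound 3 (within the scatter) and a number 2.2 percentage points higher from compound 2 to compound 3 (within the scatter), none of them beyond the scatter. A step of no size beyond the scatter is therefore expected in this assay. For compound 4 the expected value is 102%, with a range from 90% to 114%. The step this estimate means, a number 2.2 percentage points higher from compound 2 to compound 4 (within the scatter), is expected to stay within the scatter.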

Compound 4, a percentage reported as activity, at one concentration (the size of the read-out at that concentration, not a potency): 98.9%
The estimate for compound 4 lay 3.1 percentage points above the measured number; measured number inside the range.
By their numbers in this assay, from the lowest: compounds 4, 2, 3 and 1 (each within the scatter of the next).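

In this assay, going by these compounds alone, methoxy is the only group among those at this aromatic carbon that brings an oxygen atom, and fluoro, which it replaces, carries no hydrogen-bond acceptor. Even so, the exchanges give a number 0.9 percentage points lower from compound 2 to compound 4 (within the scatter), a number 3.1 percentage points lower from compound 3 to compound 4 (within the scatter) and a number 8.1 percentage points lower from compound 1 to compound 4 (within the scatter), so the four compounds cannot be told apart. No measurement offers an explanation for this. As far as these compounds go, whether an amine, a carboxylic acid or a longer chain at this carbon would give a step beyond the scatter remains open. So does the effect of changes elsewhere on the shared core.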